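Notes on compound 3 and its morpholinylcarbonyl analogue

This account rests on a few compounds, and the source may have more. Where it says the series, first, only, none or still open, it means among the compounds named here.

Three compounds of the series have been run in a functional assay on HEK293 cells for agonist activity at Free fatty acid receptor 1 (Homo sapiens), read by fluorescence and calcium flux, with a stated time of 10 min; on this read-out lower numbers stand for smaller maximal responses and higher numbers for larger maximal responses. Compound 1 `CC#C[C@@H](CC(=O)O)c1ccc(OC[C@@H]2COc3ccc(Cl)cc3O2)cc1` gives 65%. Compound 2 `CC#C[C@@H](CC(=O)O)c1ccc(OC[C@H]2COc3c(Cl)cccc3O2)cc1` gives 81%. Compound 3 `CC#C[C@@H](CC(=O)O)c1ccc(OC[C@H]2COc3ccc(C)cc3O2)cc1` gives 78%, the second highest of the three numbers; its nearest neighbour is compound 2, whose number lies within the usual scatter of it, so no order between these two can be read, while compound 1 lies beyond the scatter on the lower side. All three share the same core and differ in its substitution.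

Compound 4 `CC#C[C@@H](CC(=O)O)c1ccc(OC[C@H]2COc3ccc(C(=O)N4CCOCC4)cc3O2)cc1` has not yet been measured in this assay. Relative to compound 3 the change is (morpholin-4-yl)carbonyl in place of methyl on an aromatic carbon. Among the measured compounds shown here, no pair of measured compounds differs in exactly this way, so the effect of this exchange has not been observed directly. The three measured maximal responses span a modest band, and nothing in them points to a large movement in either direction. The expected step from compound 3 to compound 4 is a number 4 percentage points lower from compound 3 to compound 4 (within the scatter), taken to be within the scatter, with a slight lean to the lower side carried in the range. Compound 4 is estimated to reach 74% in this assay, with a range from 55% to 93%.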

Compound 4, largest response reached (Emax), in percent of the reference or control that the assay uses: 33%
For compound 4 the middle estimate is 41 percentage points above the measured one, outside the stated range (below it).
By their numbers in this assay, from the lowest: compound 4; then compound 1; then compounds 3 and 2 (each within the scatter of the next).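

In this assay, (morpholin-4-yl)carbonyl in place of methyl on this aromatic carbon, meta to a fused ring and para to a fused ring, gives a number 45 percentage points lower from compound 3 to compound 4 (beyond the scatter). Among the compounds shown here, this is the first single-change step, and it shows that the maximal response depends strongly on the group at this position, with compound 4 at 33% still giving a partial response rather than none. No supporting data bear on why the response falls with this exchange.

The change brings in a carbonyl and a six-membered non-aromatic ring at once, so the compounds shown leave open which of the two goes with the lower response; an acetyl group or a piperidin-1-ylcarbonyl group on the same aromatic carbon would begin to separate them. Going by these compounds, it also remains open whether a small group such as methoxy or a carboxylic acid on this carbon would keep the response of compound 3 or shift it, and so how far the effect extends beyond this one pair.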